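Adding a Second Methoxy: Expected Cytotoxicity of Compound 4

The compounds below may be only part of what the source reports. "The series", "measured", "known", "first", "only" and "open" are said of these compounds alone.

Three compounds have been measured in a functional assay on LNCaP cells (Homo sapiens) for cytotoxicity, read by MTT assay; on this read-out lower numbers stand for stronger inhibition and higher numbers for weaker inhibition:

compound 1 `c1ccc(-c2nnc(-c3c[nH]c4ccccc34)o2)cc1` gives > 1000000 nM
compound 2 `COc1ccc(-c2nnc(-c3c[nH]c4ccccc34)o2)cc1` gives > 1000000 nM
compound 3 `Clc1ccc(-c2nnc(-c3c[nH]c4ccccc34)o2)cc1` gives 583000 nM

Compound 2 stands at the limit of this assay rather than at a number. The same is true of compound 1, so that the limit of > 1000000 nM in this assay, at which 2 of the 3 values shown sit, is where most of the measured values sit. Only compound 3 returns a number, and the step from compound 2 to compound 3 is an at least 1.7-fold lower number from compound 2 to compound 3 (0.23 log units; that floor lies within the scatter), while the step from compound 1 to compound 2 is a step that the two limits leave unreadable from compound 1 to compound 2.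

Compound 4 `COc1ccc(-c2nnc(-c3c[nH]c4ccccc34)o2)cc1OC` differs from compound 2 by methoxy in place of hydrogen on an aromatic carbon. Among the compounds with values here, no measured step places a further methoxy onto a compound that already carries one; the only methoxy step available is the unreadable one from compound 1 to compound 2. Within the data shown here, with compound 2 at the limit and no step pointing downward from it, compound 4 is expected to remain at or near that limit, with an expected step that the limit leaves unreadable from compound 2 to compound 4 in this assay. The estimate for compound 4 is 1500000 nM, with a range from 400000 nM to 6000000 nM.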

Compound 4, half-maximal inhibitory concentration: > 1000000 nM
Compound 4: a limit, no number (the forecaster's own chance of this, stated with the estimate: 70%); the middle value does not contradict the limit.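

Compound 2 and compound 4 both stand at a limit rather than a number in this assay, so no step can be read between them: the limit of > 1000000 nM in this assay, at which 3 of the 4 values shown sit. The compounds shown leave open whether the added methoxy of compound 4 changes cytotoxicity at all, and by how much.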